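This account rests on a few compounds, and the source may have more. Where it says the series, first, only, none or still open, it means among the compounds named here.

Measured so far:
- compound 1, `CC(C)c1ccccc1N1CCC(C(=O)Nc2ccc3c(c2)NC(=O)CO3)CC1`: 78 nM
- compound 2, `O=C1COc2ccc(NC(=O)C3CCN(c4cccc(Cl)c4)CC3)cc2N1`: 97 nM
- compound 3, `O=C1COc2ccc(NC(=O)C3CCN(c4ccccc4C(F)(F)F)CC3)cc2N1`: 68 nM

All three share one core and differ only in the aromatic group carried on the amine nitrogen of the six-membered ring. In an assay on HEK293 cells for displacement of a labelled ligand from transient receptor potential cation channel subfamily V member 1 (Homo sapiens) (a higher number here means a weaker inhibitor, a lower number a stronger inhibitor), compound 3 gives 68 nM, the lowest number of the three, yet a 1.1-fold lower number from compound 1 to compound 3 (0.06 log units; within the scatter) and a 1.4-fold lower number from compound 2 to compound 3 (0.15 log units; within the scatter) both stay within the scatter, so the three compounds cannot be told apart on these numbers. The same holds for a 1.2-fold higher number from compound 1 to compound 2 (0.09 log units; within the scatter).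

Compound 4, `Cc1cccc(N2CCC(C(=O)Nc3ccc4c(c3)NC(=O)CO4)CC2)c1C`, continues this series: 2,3-dimethylphenyl in place of 2-(trifluoromethyl)phenyl on an amine nitrogen in a ring. Among the compounds with values here, every measured step so far swaps exactly this aromatic group, and each of them lay within the scatter. Within the data shown here, there is no step in the data that points in either direction for the new group. The expectation for compound 4 is therefore a number close to that of compound 3, with a 1.1-fold higher number from compound 3 to compound 4 (0.04 log units; within the scatter) not expected to go beyond the scatter.

Compound 4 is estimated at 75 nM in this assay, with a likely range from 35 nM to 160 nM.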

Compound 4, inhibition constant: 28 nM
Estimate against measurement, compound 4: 2.7-fold (0.43 log units) above; measured number outside the range, below it.
By their numbers in this assay, from the lowest: compound 4; then compounds 3, 1 and 2 (each within the scatter of the next).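

In this assay the aromatic group on the amine nitrogen of the six-membered ring can move the number beyond the scatter: 2,3-dimethylphenyl gives modest steps against all three earlier groups (a 2.4-fold lower number from compound 3 to compound 4 (0.39 log units; beyond the scatter)), (a 3.5-fold lower number from compound 2 to compound 4 (0.54 log units; beyond the scatter)) and (a 2.8-fold lower number from compound 1 to compound 4 (0.44 log units; beyond the scatter)). The swaps among 2-isopropylphenyl, 3-chlorophenyl and 2-(trifluoromethyl)phenyl had all stayed within the scatter, so this position looked insensitive until compound 4, which now stands apart as the strongest of the four. Nothing measured here accounts for what sets this group apart.

The compounds shown leave open whether both methyl groups are needed, or whether a phenyl carrying a single methyl group would do as well. From the compounds shown here alone, it also remains open how an ethyl or methoxy group on that ring would compare.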